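The compounds below may be only part of what the source reports. "The series", "measured", "known", "first", "only" and "open" are said of these compounds alone.

Measured compounds:

Compound 1, `CSc1nnc(-c2cccc3ccccc23)n1C`. In a functional assay on the whole organism for antagonist activity, with Mus musculus as the target (on this read-out higher numbers stand for an effect only at larger amounts of compound and lower numbers for an effect already at smaller amounts), compound 1 gives > 200 mg/kg, which is a limit of the assay and not a number.
Compound 2, `Cn1c(-c2cccc3ccccc23)nnc1[S+](C)[O-]`. In this assay compound 2 gives > 200 mg/kg, again a limit.
Compound 3, `CSc1nc(-c2ccccc2)nn1C`. In this assay compound 3 gives > 200 mg/kg, also a limit.

All three values sit at the same limit, (the limit of > 200 mg/kg in this assay, at which 3 of the 3 values shown sit), so no ordering among them can be read. The change from compound 1 to compound 2 is a group of 3 heavy atoms (1 carbon, 1 oxygen, 1 sulfur; no ring) in place of a group of 2 heavy atoms (1 carbon, 1 sulfur; no ring), on an aromatic carbon, and the step it made is a step that the two limits leave unreadable from compound 1 to compound 2. The difference between the core of compound 1 and the core of compound 3 is not broken down here.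

Compound 4, `Cn1nc(-c2ccccc2)nc1[S+](C)[O-]`, is not yet measured. The change from compound 3 to compound 4 is a group of 3 heavy atoms (1 carbon, 1 oxygen, 1 sulfur; no ring) in place of a group of 2 heavy atoms (1 carbon, 1 sulfur; no ring), on an aromatic carbon. It is the same kind of change as from compound 1 to compound 2. Since the earlier step from compound 1 to compound 2 left both values at the limit, the expected step from compound 3 to compound 4 in this assay is a step that the limit leaves unreadable from compound 3 to compound 4, most likely ending at the limit again. The estimate for compound 4 is 300 mg/kg, between 150 mg/kg and 1000 mg/kg.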

Compound 4, dose for half-maximal effect: > 200 mg/kg
Compound 4: only a limit was reported (the forecaster's own chance of this, stated with the estimate: 85%); the middle value lies beyond the limit too.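

In this assay compound 4 gives > 200 mg/kg, a limit of the assay and not a number. The step from compound 3 to compound 4 therefore cannot be read, and the series stays at one limit: the limit of > 200 mg/kg in this assay, at which 4 of the 4 values shown sit. The compounds shown leave open which structure, if any, would give a readable dose in this assay.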